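Swapping bromine for fluorine on the shared pyrimidine core

The compounds below may be only part of what the source reports. "The series", "measured", "known", "first", "only" and "open" are said of these compounds alone.

Measured compounds:
Compound 1 `COc1cc(C(=O)NC2CCN(C)CC2)ccc1Nc1ncc(Br)c(NC2CCCC2)n1` — 2500 nM
Compound 2 `CN1CCC(NC(=O)c2ccc(Nc3ncc(Cl)c(NC4CCCC4)n3)cc2)CC1` — 1800 nM
Compound 3 `CN1CCC(NC(=O)c2ccc(Nc3ncc(Br)c(NC4CCCC4)n3)cc2)CC1` — 500 nM

In a functional assay on A549 cells (Homo sapiens) for cytotoxicity, read by MTT assay, with a stated time of 48 h (a higher number here means a weaker inhibitor, a lower number a stronger inhibitor), compound 1 gives the highest number of the three, with compound 2 close by and within the scatter of it, while compound 3 sits clearly lower a 5.0-fold lower number from compound 1 to compound 3 (0.70 log units; beyond the scatter). Compound 4 `COc1cc(C(=O)NC2CCN(C)CC2)ccc1Nc1ncc(F)c(NC2CCCC2)n1` is the next step from compound 1: fluoro in place of bromo on an aromatic carbon. Of the measured steps, the one that speaks to this change is the halogen swap from compound 2 to compound 3, where bromo in place of chloro gave a 3.6-fold lower number from compound 2 to compound 3 (0.56 log units; beyond the scatter). Here the move runs the other way, from bromo to the smaller fluoro, so a higher number, meaning a weaker inhibitor, is the reasonable expectation in this assay, likely beyond the scatter. The methoxy group stays in place, so the step from compound 1 to compound 3 does not enter directly. Compound 4 is therefore estimated at 5500 nM, in a range from 2000 nM to 15000 nM, an expected step of a 2.2-fold higher number from compound 1 to compound 4 (0.34 log units; beyond the scatter).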

Compound 4, half-maximal inhibitory concentration: 2100 nM
The estimate for compound 4 lay 2.6-fold (0.42 log units) above the measured number; measured number inside the range.
By their numbers in this assay, from the lowest: compound 3; then compounds 2, 4 and 1 (each within the scatter of the next).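

In this assay, fluoro in place of bromo on the shared core gives a 1.2-fold lower number from compound 1 to compound 4 (0.08 log units; within the scatter) and so, with the methoxy group present, these two halogens cannot be told apart. The same position did respond in the pair without the methoxy group, where bromo in place of chloro gave a 3.6-fold lower number from compound 2 to compound 3 (0.56 log units; beyond the scatter) and so a halogen change here is not always silent, although that pair differs from this one in both the halogens and the surrounding structure. No measurement shown here accounts for this difference between the two pairs.

Still open, from the compounds shown here alone, is whether fluoro in place of bromo would also leave the number within the scatter on compound 3, which has hydrogen where compound 1 has methoxy. Also open, going by these compounds, is how a nitrile or a methyl group would read at this position.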